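Branching the ester chain: propyl to tert-butyl

The source may hold more compounds than are shown below. What is called first, only, known or untested is meant among the compounds shown, and "the series" means these compounds.

Among the compounds with values here, compound 2 `CCCOC(=O)C1=C(C)NC(C)=C(C(=O)OC)C1c1[nH]cnc1Cl` gives 437 nM in an assay on isolated protein for inhibition of Voltage-dependent L-type calcium channel subunit alpha-1C (Cavia porcellus) (on this read-out higher numbers stand for weaker inhibition and lower numbers for stronger inhibition), the lowest of the two numbers so far; compound 1 `CCOC(=O)C1=C(C)NC(C)=C(C(=O)OC)C1c1[nH]cnc1Cl` gives 661 nM, and the difference a 1.5-fold lower number from compound 1 to compound 2 (0.18 log units; within the scatter) lies within the scatter. Compound 3 `COC(=O)C1=C(C)NC(C)=C(C(=O)OC(C)(C)C)C1c1[nH]cnc1Cl` keeps the shared core and changes one ester: tert-butyl in place of propyl on an oxygen next to a carbonyl group. Within the data shown here, only the step from compound 1 to compound 2 bears on this, since it also lengthened the same chain, and its change was small. Among the measured compounds shown here, the new change goes further in size and adds branching, for which no measured step exists, so a modest shift in either direction in this assay is as plausible as none beyond the scatter. Compound 3 is therefore expected near the value of compound 2, estimated at 450 nM with a range from 150 nM to 1400 nM, which means an expected step of a 1.0-fold higher number from compound 2 to compound 3 (0.01 log units; within the scatter).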

Compound 3, half-maximal inhibitory concentration: 1860 nM
The estimate for compound 3 lay 4.1-fold (0.62 log units) below the measured number; the whole stated range lies below it.
By their numbers in this assay, from the lowest: compounds 2 and 1 (each within the scatter of the next); then compound 3.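

In this assay, this ester oxygen now shows a clear response to the group it carries: tert-butyl in place of propyl gives a 4.3-fold higher number from compound 2 to compound 3 (0.63 log units; beyond the scatter), and tert-butyl in place of ethyl gives a 2.8-fold higher number from compound 1 to compound 3 (0.45 log units; beyond the scatter). Ethyl and propyl lie within the scatter of each other, so these two straight chains do not separate, while the branched tert-butyl of compound 3 stands beyond the scatter from both, on the side of weaker inhibition. Nothing measured here accounts for this rise.

The compounds shown do not separate the effect of branching from that of the added carbon, since tert-butyl differs from propyl in both. As far as these compounds go, an isopropyl group or a straight butyl chain on the same oxygen would bear on that question, and how far the trend extends remains open.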